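Series notes: from compound 2 to compound 3

This account rests on a few compounds, and the source may have more. Where it says the series, first, only, none or still open, it means among the compounds named here.

Compound 1 `CNC(=O)c1cc(Oc2ccc(C(=O)/C=C/c3ccco3)cc2)ccn1` gives "not determined" (no result reported)
Compound 2 `CNC(=O)c1cc(Oc2ccc(C(=O)/C=C/c3ccc(Br)cc3)cc2)ccn1` gives 18500 nM

Among the compounds with values here, in a functional assay on PC-3 cells (Homo sapiens) for cytotoxicity, read by MTT assay, with a stated time of 72 h (on this read-out lower numbers stand for stronger inhibition and higher numbers for weaker inhibition), compound 2 gives 18500 nM as the only number so far. Compound 1 has no result to set against it, so compound 2 cannot yet be ranked. The next compound for measurement is compound 3 `CNC(=O)c1cc(Oc2ccc(C(=O)/C=C/c3ccc(F)cc3Cl)cc2)ccn1`. The structural change from compound 2 is 2-chloro-4-fluorophenyl in place of 4-bromophenyl on a double-bonded chain carbon bound to a double-bonded chain carbon and amounts to 2-chloro-4-fluorophenyl in place of 4-bromophenyl on a double-bonded chain carbon bound to a double-bonded chain carbon. Within the data shown here, no measured pair shows what such a swap does, so no step beyond the usual scatter is expected in this assay and neither direction is favoured. The expected change is a 1.2-fold lower number from compound 2 to compound 3 (0.06 log units; within the scatter) as a best guess only. Compound 3 is estimated at 16000 nM (expected range 7000 nM to 40000 nM).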

Compound 3, half-maximal inhibitory concentration: 4760 nM
Estimate against measurement, compound 3: 3.4-fold (0.53 log units) above; the whole stated range lies above it.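

In this assay, the group on a double-bonded chain carbon bound to a double-bonded chain carbon now has its first readable step: 2-chloro-4-fluorophenyl in place of 4-bromophenyl gives a 3.9-fold lower number from compound 2 to compound 3 (0.59 log units; beyond the scatter) in this series. Within the data shown here, compound 2 stood alone before this, and compound 1 offered no number to compare, so this is the first sign that the read-out responds to a change at this position. No measurement on hand explains the step.

This swap removes the bromine and adds both chlorine and fluorine, so the compounds shown do not separate their contributions, which 4-chlorophenyl, 4-fluorophenyl or 2-chlorophenyl could test one at a time. As far as these compounds go, it also remains open how an aminophenyl or a carboxyphenyl group would read out at the same position.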